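A few compounds are considered here, and "the series" means these few. Any claim that something is new, unique, unknown or untested is made for them only; others in the source may bear on it.

The two measured compounds:

Compound 1, `CCn1c(-c2cnc(C)nc2)nc2c(N[C@H]3CCN(C(=O)c4cocn4)C3)ncnc21`, with 0.6 L/kg in an ADME assay (Rattus norvegicus, strain Wistar Han) for pharmacokinetics; on this read-out lower numbers stand for narrower distribution and higher numbers for wider distribution into tissues.
Compound 2, `CCn1c(-c2ccc(C(F)(F)F)nc2)nc2c(O[C@H]3CCN(C(=O)N4CC(OC)C4)C3)ncnc21`, with 0.2 L/kg in this assay.

Of these two numbers, compound 1 holds the higher one. Among the compounds with values here, its only neighbour, compound 2, gives a lower value, and the gap between the two lies beyond the scatter of repeated measurements, so the two compounds do distribute differently in this read-out. The two structures differ in several places at once, so no single change can be tied to that gap; only the two values themselves are known.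

Compound 3, `CCn1c(-c2cnc(C)nc2)nc2c(N[C@H]3CCN(C(=O)C4CCOCC4)C3)ncnc21`, is the unmeasured compound. It shares the core of compound 1 and differs from it in one place: oxan-4-yl in place of 1,3-oxazol-4-yl on a carbonyl carbon. Within the data shown here, no step between two measured compounds describes this change, so its effect in this assay is open. The expectation for compound 3 is a modest widening, with the estimated step of a 1.3-fold higher number from compound 1 to compound 3 (0.12 log units; within the scatter) staying within the scatter. Compound 3 is therefore expected to give about 0.8 L/kg, within a range from 0.4 L/kg to 1.6 L/kg.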

Compound 3, volume of distribution: 0.7 L/kg
Beside the measured number, compound 3's estimate is 1.1-fold (0.06 log units) above it; the measured number falls inside the stated range.
By their numbers in this assay, from the lowest: compound 2; then compounds 1 and 3 (each within the scatter of the next).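

Within the data shown here, this is the first step that differs in one place, so one change can now be given a size, which the pair of compound 1 and compound 2 did not allow. On a carbonyl carbon whose other neighbour is an amide-type nitrogen in a ring, oxan-4-yl in place of 1,3-oxazol-4-yl gives a 1.2-fold higher number from compound 1 to compound 3 (0.07 log units; within the scatter) in this assay. Trading the five-membered aromatic ring with 2 hetero atoms for the six-membered non-aromatic ring with 1 hetero atom therefore leaves compound 1 and compound 3 indistinguishable on this read-out, and nothing measured here offers an account of why.

The compounds shown leave open whether a group of another kind on this carbonyl carbon, such as an amine-bearing piperidine or a ring carrying a carboxylic acid, would move the number beyond the scatter. They also leave open whether the same exchange of 1,3-oxazol-4-yl for oxan-4-yl would give a comparable step in a compound that differs from compound 1 elsewhere in its structure.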